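A few compounds are considered here, and "the series" means these few. Any claim that something is new, unique, unknown or untested is made for them only; others in the source may bear on it.

Measured compounds, read in an ADME assay on SW480 cells (Homo sapiens) for cytotoxicity, read by MTT assay, with a stated time of 72 h; on this read-out lower numbers stand for stronger inhibition and higher numbers for weaker inhibition:

compound 1 `COc1ccc(NC(=O)c2cccc(/C=C3\CC(=O)N(c4ccccc4)C3=O)c2)cc1` — compound 1 gives > 100000 nM, a limit of the assay rather than a number.
compound 2 `O=C(Nc1cccc(F)c1)c1cccc(/C=C2\CC(=O)N(c3ccccc3)C2=O)c1` — compound 2 gives > 100000 nM, again a limit.
compound 3 `O=C(Nc1ccc(F)cc1)c1cccc(/C=C2\CC(=O)N(c3ccccc3)C2=O)c1` — compound 3 gives > 100000 nM, again a limit.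

Compound 3 therefore stands nowhere on a scale: its value is a limit, and the other two values shown are the same limit (the limit of > 100000 nM in this assay, at which 3 of the 3 values shown sit). Because of the limit of > 100000 nM in this assay, at which 3 of the 3 values shown sit, the three steps among the measured compounds cannot be sized: a step that the two limits leave unreadable from compound 1 to compound 2, a step that the two limits leave unreadable from compound 1 to compound 3 and a step that the two limits leave unreadable from compound 2 to compound 3 all stay unreadable in this assay.

Compound 4 `CCOc1ccc(NC(=O)c2cccc(/C=C3\CC(=O)N(c4ccccc4)C3=O)c2)cc1` is the next member. Against compound 3 the change is ethoxy in place of fluoro on an aromatic carbon. The nearest comparison is compound 1, which carries a methoxy at the same position and in this assay compound 1 gives > 100000 nM, a limit. Among the compounds with values here, no measured step bears readably on the change from fluoro to ethoxy, so no step beyond the scatter can be expected; the step from compound 3 to compound 4 is estimated as a number no higher from compound 3 to compound 4 (the limit leaves the size open). Compound 4 is expected to give about 100000 nM in this assay, with a range from 30000 nM to 300000 nM, most likely reported again as a limit.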

Compound 4, half-maximal inhibitory concentration: 91500 nM
Compound 4: middle estimate off by 1.1-fold (0.04 log units), on the high side; the range from low to high includes it.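

In this assay, within the data shown here, compound 4, with its 4-ethoxyphenyl group on the amide-type nitrogen, is the only member read as a number, whereas the 4-methoxyphenyl, 3-fluorophenyl and 4-fluorophenyl groups of the other compounds give only limits. Ethoxy in place of fluoro gives an at least 1.0-fold lower number from compound 3 to compound 4 (0.03 log units; that floor lies within the scatter) in the first comparison, the change of the whole aryl group gives an at least 1.0-fold lower number from compound 2 to compound 4 (0.03 log units; that floor lies within the scatter) in the second, and the extra methyl on the chain gives an at least 1.0-fold lower number from compound 1 to compound 4 (0.03 log units; that floor lies within the scatter) in the third. Each of these is only a floor, so no gain beyond the scatter is shown at this position: the limit of > 100000 nM in this assay, at which 3 of the 4 values shown sit.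

The steps among compound 1, compound 2 and compound 3 cannot be read. Going by these compounds, whether a longer alkoxy chain such as butoxy, or an amine or a carboxylic acid at this position, would give a clearly lower number remains open.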